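A Dimethoxyphenyl Analogue in a Pyrazoline Sulfonamide Series

The source may report more compounds than this note shows. Statements on the series, on what has been measured and on what is new or still open speak of the compounds shown alone.

Of the compounds shown here, two in this set have been tested in a functional assay on SN12C cells (Homo sapiens) for antiproliferative activity, with a stated time of 48 h; on this read-out lower numbers stand for stronger inhibition of growth and higher numbers for weaker inhibition of growth. Compound 1 `Cc1cc(O)c(C2=NN(c3ccc(S(N)(=O)=O)cc3)C(c3ccccc3Cl)C2)cc1Cl` gives 6320 nM, and compound 2 `Cc1cc(O)c(C2=NN(c3ccc(S(N)(=O)=O)cc3)C(/C=C/c3ccccc3)C2)cc1Cl` gives 25600 nM. Among the measured compounds shown here, compound 2 therefore carries the highest of the two numbers so far, with compound 1 as its only neighbour; the one step recorded between them is a 4.1-fold higher number from compound 1 to compound 2 (0.61 log units; beyond the scatter). Compound 3 `COc1ccc(C2CC(c3cc(Cl)c(C)cc3O)=NN2c2ccc(S(N)(=O)=O)cc2)cc1OC` differs from compound 2 by a single change: 3,4-dimethoxyphenyl in place of 2-phenylethenyl on a saturated ring carbon. The step from compound 1 to compound 2 is the only measured one that bears on this change, since it also exchanged the group on that same saturated ring carbon, and it moved the number upward by a modest amount when an aromatic ring gave way to 2-phenylethenyl. Returning to a directly attached aromatic ring might partly reverse that, though the new ring carries different substituents, so compound 3 is expected to show a 2.3-fold lower number from compound 2 to compound 3 (0.37 log units; beyond the scatter) in this assay. The estimate for compound 3 is 11000 nM, within a range of 3500 nM to 35000 nM.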

Compound 3, concentration for total growth inhibition: 30000 nM
For compound 3 the middle estimate is 2.7-fold (0.44 log units) below the measured one; measured number inside the range.
By their numbers in this assay, from the lowest: compound 1; then compounds 2 and 3 (each within the scatter of the next).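

In this assay, the exchange of 2-phenylethenyl for 3,4-dimethoxyphenyl on the saturated ring carbon gives a 1.2-fold higher number from compound 2 to compound 3 (0.07 log units; within the scatter) and so does not separate these two groups, even though one brings an aromatic ring straight onto that carbon and two oxygen atoms with it. An aromatic ring at this position is therefore not enough to give the lower number of compound 1, as the exchange of 2-chlorophenyl for 3,4-dimethoxyphenyl gives a 4.7-fold higher number from compound 1 to compound 3 (0.68 log units; beyond the scatter) and both compounds carry such a ring.

As far as these compounds go, what separates those two rings stays open, as chlorine and the methoxy groups differ together, and a plain phenyl or a 4-dimethylaminophenyl group on this carbon would be needed to test it. Nothing measured here gives a reason for these numbers.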